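The source may hold more compounds than are shown below. What is called first, only, known or untested is meant among the compounds shown, and "the series" means these compounds.

Of the compounds shown here, three have so far been measured in a physicochemical assay for lipophilicity, using the shake flask method, measured as octanol-water partition, with a stated time of 30 min, at pH 7.4; on this read-out higher numbers stand for higher lipophilicity and lower numbers for lower lipophilicity. Compound 1 `O=C(O)CCc1ccc(-c2ccc3cnn(-c4ccccn4)c3c2)cc1` gives 2.4 in this assay. Compound 2 `O=C(O)CCc1ccc(-c2cc(F)c3cnn(-c4ccccn4)c3c2)cc1` differs from it by a single fluoro group on the shared core and gives 2.8. Compound 3 `COc1nn(-c2ccccn2)c2cc(-c3ccc([C@H]4C[C@@H]4C(=O)O)cc3)cc(F)c12` is built on a different core and gives 3.8, the highest of the three numbers; the difference between the core of compound 2 and the core of compound 3 is not broken down here.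

One change within this set is measured directly. Going from compound 2 to compound 1 the change is hydrogen in place of fluoro on an aromatic carbon, and in this assay it gave a number 0.40 log units lower from compound 2 to compound 1 (beyond the scatter).

Compound 4 `COc1nn(-c2ccccn2)c2cc(-c3ccc([C@H]4C[C@@H]4C(=O)O)cc3)ccc12` has not yet been measured. It stands to compound 3 exactly as compound 1 stands to compound 2: the change is hydrogen in place of fluoro on an aromatic carbon, the same change at the same kind of place, word for word. Going by the values given here, the only guide to what this change does in this assay is the single measured pair, compound 2 and compound 1, so the expectation rests on that one step and on the value of compound 3, 3.8. On that basis the step is estimated at a number 0.40 log units lower from compound 3 to compound 4 (beyond the scatter), close to the measured one. Compound 4 is therefore expected to give about 3.4, most likely between 3 and 3.8.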

Compound 4, distribution coefficient: 3.8
Compound 4: the middle estimate sits 0.40 log units below what was measured, within the range that was stated.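

In this assay, the change of hydrogen in place of fluoro on an aromatic carbon gave no change at the digits printed from compound 3 to compound 4 (within the scatter) while the same written change gave a number 0.40 log units lower from compound 2 to compound 1 (beyond the scatter) and so the step did not carry over from one pair to the other. This shows that an identical change can give a step beyond the scatter in one setting and a step within it in another, which makes a single measured pair a weak guide when moving to a different core. Going by these compounds alone, it does not show that the core alone sets the outcome, as the two pairs also differ in the part that carries the carboxylic acid, and with only two pairs no general rule can be drawn, while nothing available explains why the two steps differ.

The compounds shown leave open how the same change would behave in a further pair, for example one that keeps the core of compound 3 but carries the carboxylic acid on the chain found in compound 2. They also leave open whether a different group at this place, such as chloro or nitrile, would follow the pattern of either pair.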